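The compounds below may be only part of what the source reports. "The series", "measured", "known", "first", "only" and "open" are said of these compounds alone.

Compound 1, with the structure `O=C(/C=C/c1cn(-c2ccccc2)nc1-c1cccnc1)c1ccsc1`, is the most potent of the three measured compounds: in a functional assay on MCF7 cells (Homo sapiens) for inhibition, read by sulforhodamine B assay, with a stated time of 72 h (on this read-out lower numbers stand for stronger inhibition and higher numbers for weaker inhibition), compound 1 gives 500 nM. Compound 3, with the structure `O=C(/C=C/c1cn(-c2ccccc2)nc1-c1ccncc1)c1ccsc1`, shares the core of compound 1 and differs from it only in the change (pyridin-4-yl in place of pyridin-3-yl on an aromatic carbon). In this assay compound 3 gives 1500 nM, so the change weakens inhibition: a 3.0-fold higher number from compound 1 to compound 3 (0.48 log units; beyond the scatter).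

Compound 2, with the structure `COc1cc(C(=O)/C=C/c2cn(-c3ccccc3)nc2-c2cccnc2)cc(OC)c1OC`, carries a different group on the carbonyl, and the difference between its core and that of compound 1 is not broken down here. In this assay compound 2 gives 14500 nM, the highest number of the three, well beyond the scatter from both compound 1 and compound 3.

Compound 4, with the structure `COc1cc(C(=O)/C=C/c2cn(-c3ccccc3)nc2-c2ccncc2)cc(OC)c1OC`, has not been measured in this assay. It arises from compound 2 by the change (pyridin-4-yl in place of pyridin-3-yl on an aromatic carbon). The place of this change is described in nearly the same words as for the change from compound 1 to compound 3, except that the neighbouring ring atom bears a large group rather than a group of 9 heavy atoms, so the two changes are of the same kind, not the same. Since the earlier step was a 3.0-fold higher number from compound 1 to compound 3 (0.48 log units; beyond the scatter), a step of similar size is expected from compound 2 to compound 4 in this assay, namely a 2.8-fold higher number from compound 2 to compound 4 (0.44 log units; beyond the scatter), though it rests on a single pair. Compound 4 is therefore estimated to give about 40000 nM in this assay, with a plausible range from 15000 nM to 100000 nM.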

Compound 4, half-maximal inhibitory concentration: 3500 nM
Compound 4: the middle estimate sits 11-fold (1.06 log units) above what was measured; the measured number lies below the stated range.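

Replacing pyridin-3-yl by pyridin-4-yl does not act alike on the two cores: in this assay the new pair shows a 4.1-fold lower number from compound 2 to compound 4 (0.62 log units; beyond the scatter), which runs opposite to the earlier 3.0-fold higher number from compound 1 to compound 3 (0.48 log units; beyond the scatter). The two steps differ in direction, so neither the size nor the sign of this change can be carried from one core to the other in this series: the same change on two cores in this assay, a 3.0-fold higher number (0.48 log units; beyond the scatter) from compound 1 to compound 3 and a 4.1-fold lower number (0.62 log units; beyond the scatter) from compound 2 to compound 4, 12-fold (1.09 log units) apart, beyond the scatter of two such steps What this does not show is why the direction reverses, and two pairs cannot tell how the same change would behave on any further core, or which of the two steps would be the more typical one.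

The compounds shown leave open how the change behaves with other groups on the carbonyl, for example a dimethylamino group or a simple methyl group. They also leave open what pyridin-2-yl would do in the same place on either core, or whether a carboxylic acid on the phenyl group would alter the outcome.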